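From 4-chlorophenyl to 2-methoxyphenyl: an expected flat step

The compounds below may be only part of what the source reports. "The series", "measured", "known", "first", "only" and "open" are said of these compounds alone.

In a functional assay on MDA-MB-436 cells (Homo sapiens) for antiproliferative activity, read by MTT assay, with a stated time of 48 h (on this read-out lower numbers stand for stronger inhibition and higher numbers for weaker inhibition), compound 1 `C=CS(=O)(=O)N1CCN(c2ncnc3sc(-c4ccc(N5CCN(C)CC5)cc4)cc23)CC1` gives 8760 nM, compound 2 `CCS(=O)(=O)N1CCN(c2ncnc3sc(-c4ccc(N5CCN(C)CC5)cc4)cc23)CC1` gives 10600 nM and compound 3 `CN1CCN(c2ccc(-c3cc4c(N5CCN(C(=O)Nc6ccc(Cl)cc6)CC5)ncnc4s3)cc2)CC1` gives 9270 nM. These three numbers lie within the usual scatter of one another, so compound 3 stands level with the other two. Compound 4 `COc1ccccc1NC(=O)N1CCN(c2ncnc3sc(-c4ccc(N5CCN(C)CC5)cc4)cc23)CC1` keeps the shared core and differs from compound 3 in one place, with 2-methoxyphenyl in place of 4-chlorophenyl on an amide-type nitrogen. Within the data shown here, no measured pair tests this swap directly, so the evidence is indirect. Putting (4-chlorophenyl)carbamoyl in place of vinylsulfonyl gave a 1.1-fold higher number from compound 1 to compound 3 (0.02 log units; within the scatter), the same group in place of ethylsulfonyl gave a 1.1-fold lower number from compound 2 to compound 3 (0.06 log units; within the scatter), and ethyl in place of vinyl gave a 1.2-fold higher number from compound 1 to compound 2 (0.08 log units; within the scatter). None of these steps leaves the scatter, so no step beyond it is expected here, and no direction can be favoured in this assay. The expected change is a 1.0-fold higher number from compound 3 to compound 4 (0.01 log units; within the scatter). For compound 4 the estimated value is 9500 nM, with an expected range from 5000 nM to 18000 nM.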

Compound 4, half-maximal inhibitory concentration: 26300 nM
Beside the measured number, compound 4's estimate is 2.8-fold (0.44 log units) below it; the whole stated range lies below it.
By their numbers in this assay, from the lowest: compounds 1, 3 and 2 (each within the scatter of the next); then compound 4.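

Among these compounds, the group on this amide-type nitrogen can move the number: 2-methoxyphenyl in place of 4-chlorophenyl gives a 2.8-fold higher number from compound 3 to compound 4 (0.45 log units; beyond the scatter) in this assay and is the first step here to leave the scatter. The (2-methoxyphenyl)carbamoyl group also parts from the sulfonyl groups, with a 2.5-fold higher number from compound 2 to compound 4 (0.39 log units; beyond the scatter) and a 3.0-fold higher number from compound 1 to compound 4 (0.48 log units; beyond the scatter), while (4-chlorophenyl)carbamoyl stood level with them, so the carbamoyl link alone does not set the number and the aromatic group on it matters. No measurement shown offers a reason for this rise.

The swap removes chlorine and brings in methoxy in a single move, so these compounds cannot show which of the two carries the step. From the compounds shown here alone, a plain phenyl on the same nitrogen would set both against a ring with neither, and whether any group here can bring the number lower than the level shared by compounds 1, 2 and 3 remains open.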